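Cyano in place of fluoro at a tolerance ceiling

The source may report more compounds than this note shows. Statements on the series, on what has been measured and on what is new or still open speak of the compounds shown alone.

Compound 1 `O=C(Nc1cc(-c2ccccn2)n[nH]1)N1CCC(c2ccc(Cl)cc2)CC1`, compound 2 `O=C(Nc1cc(-c2ccccn2)n[nH]1)N1CCC(c2ccc(F)cc2)CC1` and compound 3 `O=C(NCc1cccc(Cl)c1)Nc1cc(-c2ccccn2)n[nH]1` share one core and were tested in an ADME assay on MRC5 cells (Homo sapiens) for cytotoxicity, read by fluorescence and resazurin assay, with a stated time of 3 days; a higher number here means that more compound is tolerated, a lower number that less compound is tolerated. Compound 1 reaches only the limit > 62000 nM. Compound 2 likewise gives only the limit > 64000 nM. Compound 3 too stops at the limit > 64000 nM. The step that the two limits leave unreadable from compound 1 to compound 2 cannot be sized, since every value shown is a limit, one at the limit of > 62000 nM in this assay, at which 1 of the 3 values shown sits, and the rest at the limit of > 64000 nM in this assay, at which 2 of the 3 values shown sit. Compound 2 thus stands at the ceiling of this assay. Compound 4 `N#Cc1ccc(C2CCN(C(=O)Nc3cc(-c4ccccn4)n[nH]3)CC2)cc1` differs from compound 2 by cyano in place of fluoro on an aromatic carbon. Among the compounds with values here, no measured step bears on this change. Compound 4 is therefore expected to remain at the ceiling, with an estimated 64000 nM between 30000 nM and 130000 nM. The expected step of a number no higher from compound 2 to compound 4 (the limit leaves the size open) is none beyond the scatter.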

Compound 4, half-maximal cytotoxic concentration: > 64000 nM
Compound 4: only a limit was reported; the forecaster's own chance of this, stated with the estimate: 80%; the middle value sits exactly at the limit.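

Within the data shown here, compound 1, compound 2 and compound 4 all stop at limits in this assay, so no step among them can be read. The compounds shown leave open whether chloro, fluoro and cyano differ at all in half-maximal cytotoxic concentration.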